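The source may hold more compounds than are shown below. What is called first, only, known or untested is meant among the compounds shown, and "the series" means these compounds.

Measured in an assay on isolated protein for inhibition of Retinaldehyde dehydrogenase 3 (Homo sapiens); a lower number here means a stronger inhibitor, a higher number a weaker inhibitor:
compound 1 `CC(Sc1nc2c(cnn2C)c(=O)n1-c1ccccc1)c1cccc(F)c1` gives 128 nM
compound 2 `COc1ccccc1C(C)Sc1nc2c(cnn2C)c(=O)n1-c1ccccc1` gives 112 nM

Of these two numbers, compound 1 stands at the higher one, but its distance to compound 2 is within the scatter of the assay, so the two cannot be ordered. Compound 3 `C[C@H](Sc1nc2c(cnn2C)c(=O)n1-c1ccccc1)c1ccccc1` differs from compound 1 in one place: 1-phenylethyl in place of 1-(3-fluorophenyl)ethyl on a sulfur. Within the data shown here, the one measured step that bears on this change is the step from compound 1 to compound 2, which also exchanged the aromatic ring on that chain carbon and gave a 1.1-fold lower number from compound 1 to compound 2 (0.06 log units; within the scatter). Among the measured compounds shown here, with that as the only guide, the step to compound 3 is expected to stay within the scatter in this assay, with no clear direction. Compound 3 is therefore expected to give about 130 nM, with a range from 60 nM to 280 nM. The estimate means an expected step of a 1.0-fold higher number from compound 1 to compound 3 (0.01 log units; within the scatter).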

Compound 3, half-maximal inhibitory concentration: 1640 nM
The estimate for compound 3 lay 13-fold (1.10 log units) below the measured number, and the stated range ends below it.
By their numbers in this assay, from the lowest: compounds 2 and 1 (each within the scatter of the next); then compound 3.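

In this assay, the exchange on the sulfur gives a 13-fold higher number from compound 1 to compound 3 (1.11 log units; beyond the scatter), so the aromatic ring of this side group is not indifferent to the number, as the earlier pair alone might have suggested. Compounds 1 and 2 each carry a group on that ring and stand within the scatter of each other, while compound 3 has a bare phenyl and stands well apart from compound 1. Nothing shown here explains this step.

The change also brings in a defined stereocentre, so the compounds shown cannot separate the loss of the fluorine from the stereochemistry, and the mirror-image form of compound 3 would bear directly on that. Also open, from the compounds shown here alone, is whether a chlorine or a methyl group in the fluorine's place would keep the number of compound 1.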